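Swapping methoxy for fluoro on the outer phenyl ring

This account rests on a few compounds, and the source may have more. Where it says the series, first, only, none or still open, it means among the compounds named here.

Of the compounds shown here, three sharing one core have been tested in a functional assay on OVCAR-5 cells (Homo sapiens) for inhibition, read by sulforhodamine B assay, with a stated time of 48 h, tested at 10 uM; a lower number here means less inhibition, a higher number more inhibition at the concentration tested (going by the name of the read-out). Compound 1 `Brc1cn2ccnc2c(-c2ccc3ncn(C4CCCCC4)c3c2)n1` gives 6.64%, compound 2 `c1ccc(-c2cn3ccnc3c(-c3ccc4ncn(C5CCCCC5)c4c3)n2)cc1` gives 7.87%, and compound 3 `COc1ccc(-c2cn3ccnc3c(-c3ccc4ncn(C5CCCCC5)c4c3)n2)cc1` gives 58.8%, the highest of the three. The step of a number 1.2 percentage points higher from compound 1 to compound 2 (within the scatter) shows that adding a bare phenyl changes little, whereas a number 52.2 percentage points higher from compound 1 to compound 3 (beyond the scatter) and a number 50.9 percentage points higher from compound 2 to compound 3 (beyond the scatter) show that the methoxy group on that phenyl carries almost all of the gain.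

Compound 4 `Fc1ccc(-c2cn3ccnc3c(-c3ccc4ncn(C5CCCCC5)c4c3)n2)cc1` differs from compound 3 in one place: fluoro in place of methoxy on an aromatic carbon. Within the data shown here, no measured step covers fluoro at this position. Among the measured compounds shown here, the only direct comparison is that the unsubstituted phenyl in compound 2 sits far below compound 3, so removing the methoxy cost roughly the full gain. Fluoro is a small group, closer in size to hydrogen than to methoxy, and it brings no hydrogen-bond acceptor. For the measured compounds named here, a large drop toward the level of compound 2 is therefore expected, with wide uncertainty because no fluoro analogue has been measured.

Compound 4 is estimated at 18%, between 3% and 50%. This corresponds to an expected step of a number 40.8 percentage points lower from compound 3 to compound 4 (beyond the scatter) in this assay.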

Compound 4, a percentage reported as inhibition, at one concentration (the size of the read-out at that concentration, not a potency): 10.3%
The estimate for compound 4 lay 7.7 percentage points above the measured number, and the stated range covers the measured number.
By their numbers in this assay, from the lowest: compounds 1, 2 and 4 (each within the scatter of the next); then compound 3.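

Fluoro in place of methoxy gives a number 48.5 percentage points lower from compound 3 to compound 4 (beyond the scatter) in this assay, so the gain seen with the 4-methoxyphenyl group does not carry over to the 4-fluorophenyl group; a substituent at this place is not enough in itself. Fluoro in place of hydrogen gives a number 2.4 percentage points higher from compound 2 to compound 4 (within the scatter) and 4-fluorophenyl in place of bromo gives a number 3.7 percentage points higher from compound 1 to compound 4 (within the scatter), which leaves compounds 1, 2 and 4 together and compound 3 alone well apart from them. Nothing available explains why methoxy and fluoro differ so much here.

Open, as far as these compounds go, is whether ethoxy, hydroxy or a dimethylamino group at this place would keep the number near that of compound 3, which gives 58.8%. Also open, from the compounds shown here alone, is whether a methoxy group on another carbon of this ring would do the same.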